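Compound 2 to compound 3: changing the carbonyl substituent

The source may report more compounds than this note shows. Statements on the series, on what has been measured and on what is new or still open speak of the compounds shown alone.

Compound 1 `NC(=O)c1c(NC(=O)c2ccccc2Cl)sc2c1CCN(Cc1c(Cl)cccc1Cl)C2`: 4740 nM
Compound 2 `NC(=O)c1c(NC(=O)c2ccccc2Cl)sc2c1CCN(Cc1ccc(Cl)cc1Cl)C2`: 16300 nM

Within the data shown here, in a functional assay on MKN-74 cells (Homo sapiens) for antiproliferative activity, with a stated time of 24 h (on this read-out higher numbers stand for weaker inhibition and lower numbers for stronger inhibition), compound 2 gives 16300 nM, the higher of the two numbers measured so far. Compound 3 `NC(=O)c1c(NC(=O)c2ccc(C(F)(F)F)cc2)sc2c1CCN(Cc1ccc(Cl)cc1Cl)C2` has not yet been measured. It differs from compound 2 by 4-(trifluoromethyl)phenyl in place of 2-chlorophenyl on a carbonyl carbon, with 4-(trifluoromethyl)phenyl in place of 2-chlorophenyl on a carbonyl carbon. Among the measured compounds shown here, the only measured step is a 3.4-fold higher number from compound 1 to compound 2 (0.54 log units; beyond the scatter). That step changes a dichlorophenyl group on a saturated chain carbon bound to an amine nitrogen in a ring, so it does not touch the carbonyl carbon. For the measured compounds named here, it shows only that one exchange can give a modest step. Going by the values given here, no measured step bears directly on the new change, so no step beyond the scatter is expected, and either direction remains open. The expected step is a 1.4-fold lower number from compound 2 to compound 3 (0.13 log units; within the scatter). For compound 3 the estimated value is 12000 nM, with an expected range from 3500 nM to 40000 nM.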

Compound 3, half-maximal inhibitory concentration: 10900 nM
Compound 3: the middle estimate sits 1.1-fold (0.04 log units) above what was measured; low and high end bracket the measured number.
By their numbers in this assay, from the lowest: compound 1; then compounds 3 and 2 (each within the scatter of the next).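

In this assay, among these compounds, the first exchange on the carbonyl carbon, 4-(trifluoromethyl)phenyl in place of 2-chlorophenyl, gives a 1.5-fold lower number from compound 2 to compound 3 (0.17 log units; within the scatter). This position therefore accepts a group of 10 heavy atoms in place of one of 7 with no step beyond the scatter, whereas the earlier pair spoke only to the dichlorophenyl group on the saturated chain carbon. Nothing available explains why this exchange leaves the number within the scatter.

The exchange alters the ring substituent and where it sits in one move, so 4-chlorophenyl would be needed to tell those two apart, and a saturated chain or a ring bearing an amine would test whether the phenyl ring matters at all. Going by these compounds, whether the same exchange holds with the 2,6-dichlorophenyl group of compound 1 also stays open.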